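Replacing 4-iodophenyl with 2,4-dimethylphenyl

The source may report more compounds than this note shows. Statements on the series, on what has been measured and on what is new or still open speak of the compounds shown alone.

- Compound 1 `Oc1cc(C(F)(F)F)ccc1-c1nc(-c2ccccc2O)n(-c2ccc(Br)cc2)n1`: 66800 nM
- Compound 2 `Oc1cc(C(F)(F)F)ccc1-c1nc(-c2ccccc2O)n(-c2ccc(I)cc2)n1`: 73300 nM

In a toxicity assay on PC-12 cells (Rattus norvegicus) for cytotoxicity, read by MTT assay (a higher number here means a weaker inhibitor, a lower number a stronger inhibitor), compound 2 gives 73300 nM, a value that cannot be told apart from that of compound 1. Compound 3 `Cc1ccc(-n2nc(-c3ccc(C(F)(F)F)cc3O)nc2-c2ccccc2O)c(C)c1` has not yet been measured. It shares its core with compound 2 and differs by one group: 2,4-dimethylphenyl in place of 4-iodophenyl on an aromatic nitrogen. In words, it carries 2,4-dimethylphenyl in place of 4-iodophenyl on an aromatic nitrogen.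

Among the compounds with values here, only one measured step bears on this change: a 1.1-fold higher number from compound 1 to compound 2 (0.04 log units; within the scatter). It exchanges bromo for iodo on an aromatic carbon of the group now being replaced, and it lies within the scatter. Neither measured compound carries a methyl group, so the data offer little direct guidance on the new group. No step beyond the scatter is therefore expected in this assay, and no direction is favoured, although the range must stay wide. The expected change is a 1.1-fold lower number from compound 2 to compound 3 (0.05 log units; within the scatter). For compound 3 the estimate is 65000 nM, with an expected range from 27000 nM to 140000 nM.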

Compound 3, half-maximal inhibitory concentration: 231000 nM
Estimate against measurement, compound 3: 3.6-fold (0.55 log units) below; measured number outside the range, above it.
By their numbers in this assay, from the lowest: compounds 1 and 2 (each within the scatter of the next); then compound 3.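

In this assay, putting 2,4-dimethylphenyl on the aromatic nitrogen in place of 4-iodophenyl gives a 3.2-fold higher number from compound 2 to compound 3 (0.50 log units; beyond the scatter) and in place of 4-bromophenyl gives a 3.5-fold higher number from compound 1 to compound 3 (0.54 log units; beyond the scatter), which makes compound 3 the weakest inhibitor of the three. The earlier pair changed only the halogen on the phenyl group and gave a 1.1-fold higher number from compound 1 to compound 2 (0.04 log units; within the scatter), a step within the scatter, so it could not show whether this position responds at all; compound 3 shows that the number does move when the group on this nitrogen is changed more broadly. No measurement shown here explains why the number rises with this change.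

This change removes the halogen and adds two methyl groups at once, so the compounds shown leave open whether the step goes with losing the halogen, with the methyl group at the 4 position of the 2,4-dimethylphenyl name, or with the one at the 2 position. Going by these compounds, how a phenyl group carrying an amine or a carboxylic acid would read in this assay also remains open.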